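The compounds below may be only part of what the source reports. "The series", "measured", "known", "first", "only" and "open" are said of these compounds alone.

Compound 1 `O=C(O)/C=C/c1ccncc1-c1ccc2cc[nH]c2c1` is measured in a functional assay on MCF7 cells (Homo sapiens) for inhibition, read by sulforhodamine B assay, with a stated time of 72 h; a higher number here means a weaker inhibitor of growth, a lower number a stronger inhibitor of growth. In this assay compound 1 gives only a limit of the assay, > 10000 nM. Compound 3 `O=C(CCc1ccncc1-c1ccc2ccccc2c1)N1CCOCC1` likewise gives only a limit in this assay, > 10000 nM. Compound 2 `CNC(=O)/C=C/c1ccncc1-c1ccc2ccccc2c1` gives 9340 nM in this assay. Compound 1 thus stands at the limit of > 10000 nM in this assay, at which 2 of the 3 values shown sit, and no step between measured compounds is shown. Compound 4 `O=C(/C=C/c1ccncc1-c1ccc2cc[nH]c2c1)N1CCOCC1` differs from compound 1 in one place: morpholin-4-yl in place of hydroxy on a carbonyl carbon. Compound 2, which gives 9340 nM in this assay, also carries an amide in place of carboxy, so no step beyond the scatter is expected in this assay. Compound 4 is therefore expected to give about 9000 nM, between 3000 nM and 30000 nM. The expected step is an at least 1.1-fold lower number from compound 1 to compound 4 (0.04 log units; that floor lies within the scatter), with a fair chance that the assay again reports only a limit.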

Compound 4, concentration for 50% growth inhibition: > 10000 nM
Compound 4: no number, only a limit (the forecaster's own chance of this, stated with the estimate: 50%); middle value at least 1.1-fold (0.04 log units) from the limit.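

In this assay, going by these compounds alone, compound 1 and compound 4 both give only a limit of the assay, so no step between them can be read. The compounds shown leave open whether morpholin-4-yl in place of hydroxy on a carbonyl carbon changes growth inhibition at all.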